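This account rests on a few compounds, and the source may have more. Where it says the series, first, only, none or still open, it means among the compounds named here.

Measured compounds:
Compound 1 `CCCC1Nc2ccc(C(C)C)cc2C(=O)N1Cc1ccc(-c2ccccc2-c2nn[nH]n2)cc1`: 88%
Compound 2 `CCCC1N(Cc2ccc(-c3ccccc3-c3nn[nH]n3)cc2)C(=O)c2ccccc2N1C`: 88%

Both readings come from a functional assay on the whole organism for inhibition, with Rattus norvegicus as the target, at a dose of 15 mg/kg by the intravenous route; on this read-out higher numbers stand for more inhibition at the one dose given (going by the name of the read-out) and lower numbers for less inhibition. On this read-out compound 2 stands level with compound 1 at the digits shown; the two values lie within the usual scatter of repeated measurements, so the inhibition in this assay is level for the pair and neither number can be called the higher of the two.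

Compound 3 `CCCC1Nc2ccccc2C(=O)N1Cc1ccc(-c2ccccc2-c2nn[nH]n2)cc1` is the compound still to be measured. Set beside compound 2, it shows (hydrogen in place of methyl on a nitrogen on an aromatic ring in a ring). Among the measured compounds shown here, no pair of measured compounds here differs in a single place, so there is no measured step that tells directly what such a change does. What is known is that the two measured compounds sit at the same level, compound 1 at 88% and compound 2 at 88%, and the change to compound 3 is small in what is counted. The expected step of a number 4 percentage points lower from compound 2 to compound 3 (within the scatter) is therefore none beyond the scatter, with a slight lean downward to allow for uncertainty. Compound 3 is expected to give about 84%, in a range from 68% to 95%.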

Compound 3, a percentage reported as inhibition, in the whole organism at one dose (the size of the read-out at that dose, not a potency): 88%
Compound 3: the middle estimate sits 4 percentage points below what was measured, and the stated range covers the measured number.
By their numbers in this assay, from the lowest: compounds 1, 2 and 3 (each within the scatter of the next).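

Replacing the methyl with hydrogen on a nitrogen on an aromatic ring in a ring gives, in this assay, no change at the digits printed from compound 2 to compound 3 (within the scatter), so at this one dose the reading does not distinguish between methyl and hydrogen at this position. The second change, hydrogen in place of isopropyl on an aromatic carbon, gives no change at the digits printed from compound 1 to compound 3 (within the scatter), so the isopropyl group, like the methyl, is not required to reach this level of inhibition in the rat at this dose. Nothing available explains why neither change moves the reading.

Since the read-out gives the size of the inhibition at a single dose rather than a potency, these compounds could still differ at lower doses or in how long the effect lasts. As far as these compounds go, it also remains open whether a longer chain such as butyl on that nitrogen, or an amine or a carboxylic acid on that aromatic carbon, would leave the inhibition equally unchanged.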